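Swapping cyclopropyl for methyl on a sulfonyl sulfur

The source may report more compounds than this note shows. Statements on the series, on what has been measured and on what is new or still open speak of the compounds shown alone.

Measured compounds:
Compound 1 `Cn1cc(-c2ccc(C(F)(F)F)cc2)c2cc(F)c(C(=O)NS(=O)(=O)C3CC3)cc21`: 46 nm/s
Compound 2 `CC(C)COc1ncc(-c2cn(C)c3cc(C(=O)NS(=O)(=O)C4CC4)c(F)cc23)cc1Cl`: 34 nm/s
Compound 3 `CC(C)COc1ncc(-c2cn(C)c3cc(C(=O)NS(C)(=O)=O)c(F)cc23)cc1Cl`: 20 nm/s

In an ADME assay on Caco-2 cells (Homo sapiens) for permeability, in the apical to basolateral direction (a lower number here means that the compound crosses the layer more slowly, a higher number that the compound crosses the layer faster), compound 1 gives 46 nm/s. Compound 2 and compound 3 share one core; how that core differs from the core of compound 1 is not broken down here. Compound 3 differs from compound 2 in one place: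

methyl in place of cyclopropyl on a sulfonyl sulfur

This gave a 1.7-fold lower number from compound 2 to compound 3 (0.23 log units; within the scatter). Compound 4 `Cn1cc(-c2ccc(C(F)(F)F)cc2)c2cc(F)c(C(=O)NS(C)(=O)=O)cc21`, not yet measured, differs from compound 1 in the same way:

methyl in place of cyclopropyl on a sulfonyl sulfur

Since the place is the same in both pairs, this is the same change. A step of similar size is expected, resting on compound 2 and compound 3 with a 1.7-fold lower number from compound 2 to compound 3 (0.23 log units; within the scatter), so the expected step is a 1.6-fold lower number from compound 1 to compound 4 (0.22 log units; within the scatter). For compound 4 the estimate in this assay is 28 nm/s, expected between 15 nm/s and 55 nm/s.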

Compound 4, apparent permeability: 20 nm/s
Estimate against measurement, compound 4: 1.4-fold (0.15 log units) above, and the stated range covers the measured number.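

In this assay, putting methyl in place of cyclopropyl on the sulfonyl sulfur gave a 2.3-fold lower number from compound 1 to compound 4 (0.36 log units; beyond the scatter). Both cores moved in the same direction, and the two steps cannot be told apart, so the change carried over from one core to the other here: the same change on two cores in this assay, a 1.7-fold lower number (0.23 log units; within the scatter) from compound 2 to compound 3 and a 2.3-fold lower number (0.36 log units; beyond the scatter) from compound 1 to compound 4, 1.4-fold (0.13 log units) apart, within the scatter of two such steps. Within the data shown here, this is a comparison of only two cores, so it does not show that the step would hold on a third, and it does not explain why the number moves.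

The compounds shown leave open what other groups on the sulfonyl sulfur would give, such as ethyl, a longer chain or an amine. They also leave open whether a larger ring there would behave like cyclopropyl.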